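Removing the Chloro from Compound 1

This account rests on a few compounds, and the source may have more. Where it says the series, first, only, none or still open, it means among the compounds named here.

compound 1 `O=C(Nc1cccc(Cl)c1)Nc1cc2ncncc2cc1OCc1ccccc1Cl` gives > 10000 nM as a limit
compound 2 `O=C(Nc1cccc(F)c1)Nc1cc2ncncc2cc1OCc1ccccc1Cl` gives 9400 nM
compound 3 `O=C(Nc1cc2ncncc2cc1OCc1ccccc1Cl)Nc1cccc2ccccc12` gives 2300 nM

In an ADME assay on cells (Astrocyte, Homo sapiens) for cytotoxicity, read by WST assay, with a stated time of 72 h (a lower number here means a stronger inhibitor, a higher number a weaker inhibitor), compound 1 gives > 10000 nM as a limit and not a number. Its standing is the limit of > 10000 nM in this assay, at which 1 of the 3 values shown sits, and nothing more exact. Compound 4 `O=C(Nc1cccc(Cl)c1)Nc1cc2ncncc2cc1OCc1ccccc1` differs from it by hydrogen in place of chloro on an aromatic carbon in words hydrogen in place of chloro on an aromatic carbon, so that 2-chlorobenzyl becomes benzyl.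

Among the compounds with values here, no measured step touches this chloro, so the evidence is indirect. Changes on the amide-type nitrogen give an at least 1.0-fold lower number from compound 1 to compound 2 (0.02 log units; that floor lies within the scatter) and that floor lies within the scatter. The naphthalen-1-yl swaps give an at least 4.3-fold lower number from compound 1 to compound 3 (0.63 log units; beyond the scatter) and a 4.1-fold lower number from compound 2 to compound 3 (0.61 log units; beyond the scatter) and both are beyond the scatter, but only modest. A small step towards a lower number in this assay is therefore expected, possibly none beyond the scatter, and another limit could be reported. The expected change is an at least 1.2-fold lower number from compound 1 to compound 4 (0.09 log units; that floor lies within the scatter) as an estimate resting on a limit. For compound 4 the estimate is 8000 nM as the expected value, with an expected range from 3000 nM to 15000 nM in this assay.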

Compound 4, half-maximal inhibitory concentration: 7400 nM
Compound 4: the middle estimate sits 1.1-fold (0.03 log units) above what was measured, and the stated range covers the measured number.
By their numbers in this assay, from the lowest: compound 3; then compounds 4 and 2 (each within the scatter of the next). At a limit, above all of these: compound 1.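

Within the data shown here, this is the first step that touches the 2-chlorobenzyl group itself; the earlier steps all changed the group on the amide-type nitrogen. In this assay, hydrogen in place of chloro gives an at least 1.3-fold lower number from compound 1 to compound 4 (0.13 log units; that floor lies within the scatter), so losing this chloro, leaving benzyl, does not raise the number, and the benzyloxy compound 4 has an exact value to compare against. How much the number really falls stays unknown because compound 1 gives only a limit: the limit of > 10000 nM in this assay, at which 1 of the 4 values shown sits.

Open, as far as these compounds go, is how a methoxy, an amine or a carboxylic acid in place of the chloro on this aromatic carbon would read in this assay. Also open, from the compounds shown here alone, is whether benzyl in place of 2-chlorobenzyl would give a similar step with the naphthalen-1-yl group of compound 3 on the amide-type nitrogen.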